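Working notes: hepatocyte clearance, from compound 2 to compound 3

This account rests on a few compounds, and the source may have more. Where it says the series, first, only, none or still open, it means among the compounds named here.

compound 1 `O=C(N[C@H]1CN(S(=O)(=O)c2ccccc2)C[C@@H]1C(=O)N[C@H]1CCCNC1)c1cc(-c2ccccc2)on1`: 6.8 uL/min
compound 2 `O=C(N[C@H]1CN(S(=O)(=O)c2ccccc2)C[C@@H]1C(=O)N[C@H]1CCCNC1)c1cc(-c2ccccc2Cl)on1`: 8.3 uL/min

In an ADME assay on cells (Hepatocyte, Rattus norvegicus) for metabolic stability (a higher number here means faster removal of the compound, a lower number slower removal), compound 2 stands highest of the two numbers, but the gap to compound 1 is within the scatter. For the measured compounds named here, the single measured step, a 1.2-fold higher number from compound 1 to compound 2 (0.09 log units; within the scatter), concerns an aromatic carbon, not the ring changed next. Compound 3 `CN1CCC[C@H](NC(=O)[C@H]2CN(S(=O)(=O)c3ccccc3)C[C@@H]2NC(=O)c2cc(-c3ccccc3Cl)on2)C1` differs from compound 2 by methyl in place of hydrogen on an amine nitrogen in a ring. Going by the values given here, no measured step touches an amine nitrogen in a ring, so nothing bears on this change directly, and the one step known was within the scatter. The expected step is therefore small: a 1.1-fold higher number from compound 2 to compound 3 (0.04 log units; within the scatter). The estimate for compound 3 is 9 uL/min, range 4.5 uL/min to 18 uL/min.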

Compound 3, intrinsic clearance in a liver preparation (reported as CLH), per the amount of preparation that the assay uses: 31 uL/min
The estimate for compound 3 lay 3.4-fold (0.54 log units) below the measured number; the whole stated range lies below it.
By their numbers in this assay, from the lowest: compounds 1 and 2 (each within the scatter of the next); then compound 3.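

In this assay, methyl in place of hydrogen on the amine nitrogen in the ring gives a 3.7-fold higher number from compound 2 to compound 3 (0.57 log units; beyond the scatter). For the compounds shown here, this is the first change to move the number beyond the scatter, which a 1.2-fold higher number from compound 1 to compound 2 (0.09 log units; within the scatter) on the aromatic carbon did not do. Nothing available explains the rise.

On these data alone, the step rests on a single pair, so whether the same methyl change would give a similar step on compound 1 remains open. Also open, as far as these compounds go, is how an ethyl or acetyl group on this nitrogen would read.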